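Triazole substituent series, cytotoxicity on pancreatic cells

A few compounds are considered here, and "the series" means these few. Any claim that something is new, unique, unknown or untested is made for them only; others in the source may bear on it.

Measured compounds:
compound 1 `COc1nc2ccc(Br)cc2cc1C(c1ccccc1)n1cc(C2CC2)nn1` — 21.8%
compound 2 `COc1nc2ccc(Br)cc2cc1C(c1ccccc1)n1cc(-c2ccc(Br)cc2)nn1` — 10.4%

In an ADME assay on PANC-1 cells (Homo sapiens) for cytotoxicity, read by sulforhodamine B assay, with a stated time of 48 h, tested at 10 uM (on this read-out lower numbers stand for less inhibition and higher numbers for more inhibition at the one concentration tested (going by the name of the read-out)), compound 1 gives 21.8% and compound 2 gives 10.4%. For the measured compounds named here, compound 2 stands lowest of the two numbers, and the single measured step, a number 11.4 percentage points lower from compound 1 to compound 2 (beyond the scatter), lies beyond the scatter, so compound 2 inhibits less than compound 1 on this read-out.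

Compound 3 `COc1nc2ccc(Br)cc2cc1C(c1ccccc1)n1cc(CCCCCO)nn1` is not yet measured. It differs from compound 2 in one place: 5-hydroxypentyl in place of 4-bromophenyl on an aromatic carbon.

Going by the values given here, only the step from compound 1 to compound 2 bears on this change, and only loosely, since it swapped cyclopropyl for 4-bromophenyl, whereas the present change removes the 4-bromophenyl again and installs a chain without a ring. Taking the 4-bromophenyl away is expected to undo part of the drop seen in a number 11.4 percentage points lower from compound 1 to compound 2 (beyond the scatter), with the number for compound 3 moving back toward the level of compound 1 rather than further down. A rise of roughly a number 6.6 percentage points higher from compound 2 to compound 3 (within the scatter) is therefore expected, modest and near the edge of the scatter. Compound 3 is estimated at 17%, within a range of 5% to 32%.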

Compound 3, a percentage reported as inhibition, at one concentration (the size of the read-out at that concentration, not a potency): 19.6%
Estimate against measurement, compound 3: 2.6 percentage points below; the range from low to high includes it.
By their numbers in this assay, from the lowest: compounds 2, 3 and 1 (each within the scatter of the next, the first and the last beyond it).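

On the aromatic carbon of the five-membered ring with 3 nitrogen, an open chain with no ring, 5-hydroxypentyl, gives a number in this assay that cannot be separated from either ring-bearing neighbour, since a number 9.2 percentage points higher from compound 2 to compound 3 (within the scatter) and a number 2.2 percentage points lower from compound 1 to compound 3 (within the scatter) both stay inside the usual spread of repeats. A ring at this carbon is therefore not required to reach the level of compound 1, and the change away from 4-bromophenyl cannot be read as a real recovery, leaving compound 3 as an intermediate case that does not settle the gap between compound 1 and compound 2. Nothing on hand gives a reason for any of these numbers.

The compounds shown leave open what the hydroxyl of the chain contributes, as a plain pentyl chain, a longer chain or a chain ending in an amine or a carboxylic acid could each sit at this carbon. They also leave open whether a phenyl without bromine would behave like 4-bromophenyl, and whether any of these small differences would hold at other concentrations.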